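Chloro to fluoro on compound 3

The source may hold more compounds than are shown below. What is called first, only, known or untested is meant among the compounds shown, and "the series" means these compounds.

Three compounds sharing one core have numbers in a functional assay on MDA-MB-231 cells (Homo sapiens) for antiproliferative activity, read by MTT assay, with a stated time of 72 h; on this read-out lower numbers stand for stronger inhibition and higher numbers for weaker inhibition. Compound 1 `CC1=CC[C@H]2[C@H](CC[C@]2(C)O)C(C)(C)[C@@H]1CC[C@H]1[C@]2(C)CC[C@H](OC(=O)NS(=O)(=O)c3ccc(C)cc3)C(C)(C)O[C@H]2CC[C@@]1(C)O` gives 47100 nM, compound 2 `COc1ccc(C(=O)O[C@H]2CC[C@]3(C)[C@H](CC[C@@](C)(O)[C@H]3CC[C@@H]3C(C)=CC[C@H]4[C@H](CC[C@]4(C)O)C3(C)C)OC2(C)C)cc1` gives 30600 nM, and compound 3 `CC1=CC[C@H]2[C@H](CC[C@]2(C)O)C(C)(C)[C@@H]1CC[C@H]1[C@]2(C)CC[C@H](OC(=O)c3ccccc3Cl)C(C)(C)O[C@H]2CC[C@@]1(C)O` gives 24300 nM. Compound 3 stands level with both of the others, as the data show a 1.9-fold lower number from compound 1 to compound 3 (0.29 log units; within the scatter) and a 1.3-fold lower number from compound 2 to compound 3 (0.10 log units; within the scatter).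

Compound 4 `CC1=CC[C@H]2[C@H](CC[C@]2(C)O)C(C)(C)[C@@H]1CC[C@H]1[C@]2(C)CC[C@H](OC(=O)c3ccccc3F)C(C)(C)O[C@H]2CC[C@@]1(C)O` differs from compound 3 in one place: fluoro in place of chloro on an aromatic carbon. The fluoro takes the place of the chloro on an aromatic carbon, ortho to a large group. Among the compounds with values here, no measured step exchanges one of these two groups for the other, so the evidence is indirect. The nearest step is a 1.3-fold lower number from compound 2 to compound 3 (0.10 log units; within the scatter), where one substituted phenyl on the carbonyl carbon replaces another. An exchange of the whole group on that carbon also stayed within the scatter, in a 1.5-fold lower number from compound 1 to compound 2 (0.19 log units; within the scatter). All three steps are thus small, and no step beyond the scatter is expected in this assay for this exchange.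

The estimate amounts to a 1.1-fold higher number from compound 3 to compound 4 (0.03 log units; within the scatter), which is expected to lie within the scatter. For compound 4 the expected value is 26000 nM, with an estimated range from 14000 nM to 48000 nM.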

Compound 4, half-maximal inhibitory concentration: 28700 nM
For compound 4 the middle estimate is 1.1-fold (0.04 log units) below the measured one; the range from low to high includes it.
By their numbers in this assay, from the lowest: compounds 3, 4, 2 and 1 (each within the scatter of the next).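

In this assay, the exchange of chloro for fluoro on the aromatic carbon ortho to a large group is now measured directly, and it gives a 1.2-fold higher number from compound 3 to compound 4 (0.07 log units; within the scatter), so the two halogens cannot be told apart at this position on this read-out. The new compound also stays level with the two other esters or carbamates of the shared core, with a 1.1-fold lower number from compound 2 to compound 4 (0.03 log units; within the scatter) and a 1.6-fold lower number from compound 1 to compound 4 (0.22 log units; within the scatter), so that all four compounds now sit within the scatter of one another and the flat picture extends to a direct change of a single atom on the ring. No measurement is at hand that would account for this lack of difference.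

The compounds shown leave open whether any group on this aromatic carbon can move the number beyond the scatter, for instance an amine, a carboxylic acid or a longer alkyl chain in place of the halogen. They also leave open whether the ring on the carbonyl carbon matters at all, which a comparison with the free hydroxyl of the shared core would help to settle.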